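The source may report more compounds than this note shows. Statements on the series, on what has been measured and on what is new or still open speak of the compounds shown alone.

Measured in an ADME assay on HEK293 cells (Homo sapiens) for cytotoxicity, read by ATP content, with a stated time of 6 h; on this read-out lower numbers stand for higher toxicity in this test and higher numbers for lower toxicity in this test:
compound 1 `Cc1nc(CNc2nc(N)nc3ccn(Cc4ccccn4)c23)cs1`: > 24000 nM, a limit
compound 2 `Cc1cnc(CNc2nc(N)nc3ccn(Cc4ccccn4)c23)o1`: > 24000 nM, a limit
compound 3 `Nc1nc(NCc2nccs2)c2c(ccn2Cc2ccccn2)n1`: > 24000 nM, a limit

Compound 3 therefore has no exact number, only a limit of the assay. The other two compounds stand in the same way, and the set as a whole shows (the limit of > 24000 nM in this assay, at which 3 of the 3 values shown sit).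

Compound 4 `Nc1nc(NCc2ccon2)c2c(ccn2Cc2ccccn2)n1` carries 1,2-oxazol-3-yl in place of 1,3-thiazol-2-yl on a saturated chain carbon bound to a nitrogen on an aromatic ring.

Three measured steps exchange one such group for another at this same place: a step that the two limits leave unreadable from compound 1 to compound 2, a step that the two limits leave unreadable from compound 1 to compound 3 and a step that the two limits leave unreadable from compound 2 to compound 3. None of them has a readable size, but none of them brought a number into view either. On that basis, no step beyond the scatter is expected in this assay, in either direction, and the expected step is a step that the limit leaves unreadable from compound 3 to compound 4. Compound 4 will most likely report only a limit as well. The estimate for compound 4 is 26000 nM, with an expected range from 14000 nM to 50000 nM.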

Compound 4, half-maximal cytotoxic concentration: > 24000 nM
Compound 4: only a limit was reported; the forecaster's own chance of this, stated with the estimate: 85%; the middle value lies beyond the limit too.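

Within the data shown here, compound 4, like compound 1, compound 2 and compound 3, gives only a limit, so no step among them can be read: the limit of > 24000 nM in this assay, at which 4 of the 4 values shown sit.

The compounds shown leave open at what concentration each would become toxic in this assay, and whether exchanging these groups changes that concentration at all.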